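Halogen swap on the benzoxazole of a piperazinyl acetamide

The compounds below may be only part of what the source reports. "The series", "measured", "known", "first", "only" and "open" are said of these compounds alone.

Measured compounds:
- compound 1 `CN(C)CCCN1CCN(CC(=O)Nc2ccc(-c3nc4cc(F)ccc4o3)cc2)CC1`: 14800 nM
- compound 2 `Cc1cc(-c2nc3cc(F)ccc3o2)ccc1NC(=O)CN1CCN(CCCN(C)C)CC1`: 7770 nM

In a functional assay on MCF7 cells (Homo sapiens) for cytotoxicity, read by MTT assay, with a stated time of 24 h (on this read-out higher numbers stand for weaker inhibition and lower numbers for stronger inhibition), compound 1 gives 14800 nM, the highest of the two numbers on hand. Its nearest neighbour is compound 2, which in this assay gives 7770 nM; the step of a 1.9-fold lower number from compound 1 to compound 2 (0.28 log units; within the scatter) is within the scatter, so the two compounds cannot be told apart on these data.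

Compound 3 `CN(C)CCCN1CCN(CC(=O)Nc2ccc(-c3nc4cc(Cl)ccc4o3)cc2)CC1` is not yet measured. It differs from compound 1 by chloro in place of fluoro on an aromatic carbon. For the measured compounds named here, none of the measured steps touches the halogen on the fused ring: the only step on hand, a 1.9-fold lower number from compound 1 to compound 2 (0.28 log units; within the scatter), concerns a methyl for hydrogen elsewhere and was itself within the scatter. Nothing in these data therefore points to a change of either direction, and the expectation for compound 3 is a number close to that of compound 1, with a 1.1-fold lower number from compound 1 to compound 3 (0.02 log units; within the scatter) expected to remain within the scatter.

Compound 3 is accordingly estimated at 14000 nM, with a range from 5000 nM to 40000 nM.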

Compound 3, half-maximal inhibitory concentration: 1650 nM
Compound 3: the middle estimate sits 8.5-fold (0.93 log units) above what was measured, outside the stated range (below it).
By their numbers in this assay, from the lowest: compound 3; then compounds 2 and 1 (each within the scatter of the next).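

In this assay, for the compounds shown here, the exchange of 5-fluoro-1,3-benzoxazol-2-yl for 5-chloro-1,3-benzoxazol-2-yl gives a 9.0-fold lower number from compound 1 to compound 3 (0.95 log units; beyond the scatter) and so is the first change in this small set to lie beyond the scatter. The earlier step, a 1.9-fold lower number from compound 1 to compound 2 (0.28 log units; within the scatter), lay within the scatter and, with a methyl in place of hydrogen, left open whether any single-atom change on these compounds could move the number; this result shows that the halogen on the aromatic carbon of the fused system can, with chloro giving the lower number of the two. No measurement on hand accounts for the difference between the two halogens.

The compounds shown carry only fluoro and chloro at this position, so it remains open where bromo, a methoxy group or plain hydrogen would fall and whether the number follows any order across such groups. On these data alone, it is also open whether chloro would give a step of similar size on compound 2, which carries the added methyl, or in other cell lines.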